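The source may hold more compounds than are shown below. What is called first, only, known or untested is meant among the compounds shown, and "the series" means these compounds.

Compound 1 `COC/C1=C/C[C@](C)(CCC=C(C)C)/C=C/[C@@H](OC(=O)C=C(C)C)[C@](C)(O)/C=C/C1=O`: 4130 nM
Compound 2 `CCN(CC)C/C1=C/C[C@](C)(CCC=C(C)C)/C=C/[C@@H](OC(=O)C=C(C)C)[C@](C)(O)/C=C/C1=O`: 130 nM
Compound 3 `CC(C)=CCC[C@]1(C)/C=C/[C@@H](OC(=O)C=C(C)C)[C@](C)(O)/C=C/C(=O)/C(CN2CCCC2)=C\C1`: 220 nM

All three values come from a functional assay on MCF7 cells (Homo sapiens) for antiproliferative activity, read by MTT assay, with a stated time of 48 h; on this read-out lower numbers stand for stronger inhibition and higher numbers for weaker inhibition. Compound 3 sits with compound 2 at the low end of this short series, the gap being only a 1.7-fold higher number from compound 2 to compound 3 (0.23 log units; within the scatter), while compound 1 stands well above both. The unmeasured compound 4 `CC(C)=CCC[C@]1(C)/C=C/[C@@H](OC(=O)C=C(C)C)[C@](C)(O)/C=C/C(=O)/C(COC(=O)c2ccc([N+](=O)[O-])cc2)=C\C1` differs from compound 3 on a saturated chain carbon bound to a double-bonded ring carbon: ((4-nitrophenyl)carbonyl)oxy in place of pyrrolidin-1-yl on a saturated chain carbon bound to a double-bonded ring carbon. Among the compounds with values here, two measured steps bear on this change, both large and both at that same place: a 32-fold lower number from compound 1 to compound 2 (1.50 log units; beyond the scatter) and a 19-fold lower number from compound 1 to compound 3 (1.27 log units; beyond the scatter). Within the data shown here, compound 4 gives up the pyrrolidin-1-yl group and, like compound 1, carries no amino group there, but no measured compound has a ((4-nitrophenyl)carbonyl)oxy group. A large step towards a higher number, and so weaker inhibition, is therefore expected in this assay, though the size of that step is uncertain. The expected step is a 9.1-fold higher number from compound 3 to compound 4 (0.96 log units; beyond the scatter). For compound 4 the estimate is 2000 nM, with an expected range from 500 nM to 8000 nM.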

Compound 4, half-maximal inhibitory concentration: 670 nM
Beside the measured number, compound 4's estimate is 3.0-fold (0.47 log units) above it; the range from low to high includes it.
By their numbers in this assay, from the lowest: compounds 2 and 3 (each within the scatter of the next); then compound 4; then compound 1.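

In this assay, the new result shows that this position does not need an amino group for a lower number than the methoxy compound gives: the ester brings a 6.2-fold lower number from compound 1 to compound 4 (0.79 log units; beyond the scatter). The two amines still keep the lower numbers, with a 3.0-fold higher number from compound 3 to compound 4 (0.48 log units; beyond the scatter) and a 5.2-fold higher number from compound 2 to compound 4 (0.71 log units; beyond the scatter), so compound 4 falls in the middle of the series. The earlier compounds shown here set only methoxy against amines, so they could not show that a group without an amino nitrogen can recover part of the drop seen with the amines, though not all of it.

No data given here explain this ordering. The compounds shown also leave open whether the 4-nitrophenyl part matters, or whether a plain benzoyloxy group, an acetyloxy group or a free hydroxyl on the same carbon would give a similar number.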